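The source may report more compounds than this note shows. Statements on the series, on what has been measured and on what is new or still open speak of the compounds shown alone.

Of the compounds shown here, three have so far been measured in a functional assay on L1210 cells (Mus musculus) for inhibition; on this read-out lower numbers stand for stronger inhibition and higher numbers for weaker inhibition. Compound 1 `CC(=O)OCCOCn1cnc2c(Cl)ncnc21` gives 44 ug/mL, compound 2 `Nc1nc2c(nc(Br)n2COCCO)c(=O)[nH]1` gives 355 ug/mL, and compound 3 `Nc1nc2c(nc(I)n2COCCO)c(=O)[nH]1` gives 39 ug/mL. Compound 3 stands at the lowest of the three numbers: compound 2 lies furthest from it, a 9.1-fold lower number from compound 2 to compound 3 (0.96 log units; beyond the scatter), while compound 1 sits within the scatter of compound 3, so no order between those two can be read.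

Compound 4 `CNc1nc2c(=O)[nH]c(N)nc2n1COCCO` differs from compound 3 by methylamino in place of iodo on an aromatic carbon. Going by the values given here, only one measured step touches this carbon, a 9.1-fold lower number from compound 2 to compound 3 (0.96 log units; beyond the scatter), and it shows that exchanging the group there can move the number well beyond the scatter. Among the compounds with values here, no step shows what a methylamino group does in place of iodo, so the direction stays open; a move back toward a higher number seems at least as likely as a further fall, since compound 2 with bromo gave 355 ug/mL. Compound 4 is therefore expected to give 150 ug/mL, in the range 30 ug/mL to 700 ug/mL, an expected step of a 3.8-fold higher number from compound 3 to compound 4 (0.59 log units; beyond the scatter).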

Compound 4, concentration for 50% inhibition: > 500 ug/mL
Compound 4: a limit, no number; the forecaster's own chance of this, stated with the estimate: 15%; middle value at least 3.3-fold (0.52 log units) away from the limit.
By their numbers in this assay, from the lowest: compounds 3 and 1 (each within the scatter of the next); then compound 2. At a limit, above all of these: compound 4.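

For compound 4 in this assay there is only a limit, not a number: the limit of > 500 ug/mL in this assay, at which 1 of the 4 values shown sits. Methylamino in place of iodo on this aromatic carbon, which lies between two ring nitrogen atoms, brings an at least 12-fold higher number from compound 3 to compound 4 (1.10 log units; beyond the scatter), so the number at this carbon can rise sharply with a nitrogen group as well as shift between two halogens. Against bromo the same exchange gives an at least 1.4-fold higher number from compound 2 to compound 4 (0.14 log units; that floor lies within the scatter), and this floor does not settle whether methylamino and bromo differ at all.

Going by these compounds, how far the true value of compound 4 lies beyond its limit stays open. Also open, on these data alone, is whether the rise belongs to the methylamino group in particular or would also appear with a plain amino group, a dimethylamino group or a longer alkylamino chain on this carbon.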